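This account rests on a few compounds, and the source may have more. Where it says the series, first, only, none or still open, it means among the compounds named here.

Measured so far in a functional assay on SK-OV-3 cells (Homo sapiens) for antiproliferative activity, read by MTT assay, with a stated time of 24 h; on this read-out lower numbers stand for stronger inhibition and higher numbers for weaker inhibition:

Compound 1 `COc1ccc(C(=O)/C=C/c2ccc(-n3ccnc3)cc2)c2c1C=CC(C)(C)O2` gives 7200 nM.
Compound 2 `COc1ccc(C(=O)/C=C/c2ccc3ccccc3n2)c2c1C=CC(C)(C)O2` gives 2350 nM.
Compound 3 `COc1ccc(C(=O)/C=C/c2ccco2)c2c1C=CC(C)(C)O2` gives > 10000 nM, which is a limit of the assay rather than a number.

Among the measured compounds shown here, compound 3 stands at the limit of > 10000 nM in this assay, at which 1 of the 3 values shown sits, so it is the one compound here without a measured value. Compound 1 and compound 2 carry a six-membered aromatic ring on the same double-bonded chain carbon and both return measured values, and among these three only compound 3 carries a five-membered aromatic ring there.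

Compound 4 `COc1ccc(C(=O)/C=C/c2ccc(O)c(Br)c2)c2c1C=CC(C)(C)O2` differs from compound 3 in one place: 3-bromo-4-hydroxyphenyl in place of furan-2-yl on a double-bonded chain carbon bound to a double-bonded chain carbon. This brings compound 4 closer to compound 1 and compound 2, whose values are measured numbers. A step toward stronger inhibition, beyond the scatter, is therefore expected in the move an at least 2.0-fold lower number from compound 3 to compound 4 (0.30 log units; that floor lies within the scatter) in this assay, though the starting point is only a limit. Compound 4 is estimated at 5000 nM, with a range from 1500 nM to 15000 nM.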

Compound 4, half-maximal inhibitory concentration: > 10000 nM
Compound 4 gave a limit, no number; the forecaster's own chance of this, stated with the estimate: 30%; middle value at least 2.0-fold (0.30 log units) away from the limit.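

In this assay compound 4 gives > 10000 nM, which is a limit and not a number. Compound 3 gives > 10000 nM, also a limit, and no step can be read between compound 3 and compound 4. Whether furan-2-yl or 3-bromo-4-hydroxyphenyl goes with stronger inhibition stays open: the limit of > 10000 nM in this assay, at which 2 of the 4 values shown sit.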